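This account rests on a few compounds, and the source may have more. Where it says the series, first, only, none or still open, it means among the compounds named here.

The measured compounds:
compound 1 `Nc1ncn(CCC2(N)OC(=O)C(OCc3ccccc3)=C2OCc2ccccc2)c(=O)n1`, > 100000 nM;
compound 2 `O=C1O/C(=C\Cn2ncc(=O)[nH]c2=O)C(OCc2ccccc2)=C1OCc1ccccc1`, 45000 nM;
compound 3 `Nc1ccn(C[C@H](O)[C@H]2OC(=O)C(OCc3ccccc3)=C2OCc2ccccc2)c(=O)n1`, > 100000 nM.

In a functional assay on HeLa cells (Homo sapiens) for inhibition, read by MTT assay, with a stated time of 72 h (on this read-out higher numbers stand for weaker inhibition and lower numbers for stronger inhibition), compound 1 gives > 100000 nM, which is a limit of the assay and not a number. Compound 3 also gives only a limit in this assay, > 100000 nM. Compound 2 gives a number, 45000 nM. Compound 1 thus stands at the limit of this assay, (the limit of > 100000 nM in this assay, at which 2 of the 3 values shown sit), without a measured number of its own. Compound 4 `Cc1cn(CCC2(N)OC(=O)C(OCc3ccccc3)=C2OCc2ccccc2)c(=O)[nH]c1=O` differs from compound 1 by a group of 9 heavy atoms (5 carbon, 2 nitrogen, 2 oxygen; one six-membered aromatic ring with 2 hetero atoms) in place of a group of 8 heavy atoms (3 carbon, 4 nitrogen, 1 oxygen; one six-membered aromatic ring with 3 hetero atoms), on a saturated chain carbon, two bonds along the chain from a saturated ring carbon. Going by the values given here, no step between measured compounds is at hand, so the size of this change cannot be read from the data. Compound 4 is expected to give 100000 nM, with a range from 40000 nM to 300000 nM. The expected step of a number no higher from compound 1 to compound 4 (the limit leaves the size open) is none beyond the scatter.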

Compound 4, half-maximal inhibitory concentration: > 100000 nM
Compound 4 ended at the assay's limit (the forecaster's own chance of this, stated with the estimate: 65%); the middle value lies on the limit itself.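

Going by these compounds alone, compound 1 and compound 4 both give only a limit in this assay, not a number, so no step between them can be read: the limit of > 100000 nM in this assay, at which 3 of the 4 values shown sit. As far as these compounds go, whether the two ring groups differ in inhibition of these cells stays open.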